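Fluoro to methyl: the step to compound 4

A few compounds are considered here, and "the series" means these few. Any claim that something is new, unique, unknown or untested is made for them only; others in the source may bear on it.

Measured in a functional assay on HeLa cells (Homo sapiens) for antiproliferative activity, read by MTT assay, with a stated time of 72 h (a lower number here means a stronger inhibitor, a higher number a weaker inhibitor), were these compounds:
- Compound 1 (`O=C1COc2ccc(-c3cnc(Cl)c(NS(=O)(=O)c4ccc(F)cc4)c3)cc2N1C1CCCCC1`) gives 14300 nM
- Compound 2 (`CC(C)N1C(=O)COc2ccc(-c3cnc(Cl)c(NS(=O)(=O)c4ccc(F)cc4)c3)cc21`) gives 5380 nM
- Compound 3 (`O=C1COc2ccc(-c3cnc(Cl)c(NS(=O)(=O)c4ccc(F)cc4)c3)cc2N1c1ccc(F)cc1`) gives > 40000 nM as a limit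

Compound 3 has no number, only a limit (the limit of > 40000 nM in this assay, at which 1 of the 3 values shown sits). Compound 4 (`Cc1ccc(N2C(=O)COc3ccc(-c4cnc(Cl)c(NS(=O)(=O)c5ccc(F)cc5)c4)cc32)cc1`) differs from it by methyl in place of fluoro on an aromatic carbon. Within the data shown here, no measured step changes that place. The nearest steps introduce the 4-fluorophenyl group (an at least 2.7-fold higher number from compound 1 to compound 3 (0.44 log units; beyond the scatter); an at least 7.4-fold higher number from compound 2 to compound 3 (0.87 log units; beyond the scatter)), and both lie beyond the scatter. Compound 4 keeps a ring there as 4-methylphenyl, so no step beyond the scatter is expected in this assay in either direction. The expected step is an at least 1.2-fold lower number from compound 3 to compound 4 (0.09 log units; that floor lies within the scatter) by this estimate. For compound 4 the expected value is 32000 nM with an estimated range from 12000 nM to 70000 nM in this assay.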

Compound 4, half-maximal inhibitory concentration: 32300 nM
Beside the measured number, compound 4's estimate is 1.0-fold (0.00 log units) below it, and the stated range covers the measured number.
By their numbers in this assay, from the lowest: compound 2; then compound 1; then compound 4. At a limit, above all of these: compound 3.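

In this assay, the 4-methylphenyl ring gives a measured step against each alkyl group on the amide-type nitrogen, and both steps lie beyond the scatter (a 6.0-fold higher number from compound 2 to compound 4 (0.78 log units; beyond the scatter); a 2.3-fold higher number from compound 1 to compound 4 (0.35 log units; beyond the scatter)). The change from fluoro to methyl itself stays unresolved, as the floor of the step (an at least 1.2-fold lower number from compound 3 to compound 4 (0.09 log units; that floor lies within the scatter)) lies within the scatter. Compound 3 has only a limit, not a number: the limit of > 40000 nM in this assay, at which 1 of the 4 values shown sits.

The compounds shown leave open how a methoxy group, an amine or a carboxylic acid would fare at this place on the ring. They also leave open whether a longer chain on the nitrogen would follow isopropyl or cyclohexyl.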